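This account rests on a few compounds, and the source may have more. Where it says the series, first, only, none or still open, it means among the compounds named here.

Measured so far in a functional assay on SW-620 cells (Homo sapiens) for antiproliferative activity, read by MTT assay, with a stated time of 24 h; a lower number here means a stronger inhibitor, a higher number a weaker inhibitor:

Compound 1 `COc1ccc(C(=O)/C=C/c2cc(OC)c(OC)c(OC)c2)c2c1C=CC(C)(C)O2`: 9150 nM
Compound 2 `COc1cc(OC)c(OC)cc1/C=C/C(=O)c1ccc(OC)c2c1OC(C)(C)C=C2`: > 10000 nM
Compound 3 `COc1ccc(C(=O)/C=C/c2ccc(F)cc2)c2c1C=CC(C)(C)O2`: > 10000 nM

Only compound 1 gives a true number in this assay. The entry for compound 2 is a limit of the assay and not a number. Compound 3 likewise has only a limit and stands at the limit of > 10000 nM in this assay, at which 2 of the 3 values shown sit. This shows where compound 3 lies on the scale, but not how far beyond the limit its real value may be.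

Compound 4 `COc1ccc(C(=O)/C=C/c2ccc(Br)cc2)c2c1C=CC(C)(C)O2` is still to be measured. It differs from compound 3 in one place: bromo in place of fluoro on an aromatic carbon. Put briefly, the 4-fluorophenyl becomes a 4-bromophenyl.

Within the data shown here, no two measured compounds differ in just one place, so the data give no direct guide to the size of such a change. The expectation therefore rests on compound 3, whose > 10000 nM is a limit. The estimated step that the limit leaves unreadable from compound 3 to compound 4 is expected to stay within the usual scatter, with no clear direction, and another reading that gives only a limit is quite likely. For compound 4 the estimated value is 12000 nM, with an expected range from 6000 nM to 25000 nM.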

Compound 4, half-maximal inhibitory concentration: > 10000 nM
Compound 4 ended at the assay's limit; the forecaster's own chance of this, stated with the estimate: 65%; the middle value lies beyond the limit too.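

In this assay compound 3 and compound 4 both end at a limit of the assay and not at a number, so no step can be read for bromo in place of fluoro. The compounds shown leave open how far beyond that limit each real value lies, and whether the 4-fluorophenyl and 4-bromophenyl differ at all.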